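Swapping trifluoromethyl for propyl on an aryl amide

The source may hold more compounds than are shown below. What is called first, only, known or untested is meant among the compounds shown, and "the series" means these compounds.

Compound 1 `O=C(Nc1cccc(-c2oc3cc(-c4ccc(F)cc4)ccc3c(=O)c2O)c1)c1ccc(C(F)(F)F)cc1` gives 32600 nM in a functional assay on MCF7 cells (Homo sapiens) for antiproliferative activity, read by CCK-8 assay, with a stated time of 72 h; on this read-out higher numbers stand for weaker inhibition and lower numbers for stronger inhibition.
Compound 2 `COc1cc(OC)cc(C(=O)Nc2cccc(-c3oc4cc(-c5ccc(F)cc5)ccc4c(=O)c3O)c2)c1` gives 3470 nM.
Compound 3 `O=C(Nc1cccc(-c2oc3cc(-c4ccc(F)cc4)ccc3c(=O)c2O)c1)c1ccc(-c2ccccc2)cc1` gives 38500 nM.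

Among these three, compound 1 stands second highest, close to compound 3 and far from compound 2. Compound 4 `CCCc1ccc(C(=O)Nc2cccc(-c3oc4cc(-c5ccc(F)cc5)ccc4c(=O)c3O)c2)cc1` differs from compound 1 by propyl in place of trifluoromethyl on an aromatic carbon. Among the measured compounds shown here, two measured steps bear on this change. One is a 9.4-fold lower number from compound 1 to compound 2 (0.97 log units; beyond the scatter), where the whole aryl group on the carbonyl was exchanged and the number moved far. The other is a 1.2-fold higher number from compound 1 to compound 3 (0.07 log units; within the scatter), where only the trifluoromethyl was exchanged and the number hardly moved. Compound 4 keeps the aryl group and again exchanges only the trifluoromethyl, so the second step is the closer guide, and no movement beyond the scatter is expected: a 1.1-fold lower number from compound 1 to compound 4 (0.04 log units; within the scatter). Compound 4 is therefore estimated at 30000 nM, between 10000 nM and 90000 nM.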

Compound 4, half-maximal inhibitory concentration: 36800 nM
Compound 4: the middle estimate sits 1.2-fold (0.09 log units) below what was measured; measured number inside the range.
By their numbers in this assay, from the lowest: compound 2; then compounds 1, 4 and 3 (each within the scatter of the next).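

In this assay, propyl in place of trifluoromethyl gives a 1.1-fold higher number from compound 1 to compound 4 (0.05 log units; within the scatter) and propyl in place of phenyl gives a 1.0-fold lower number from compound 3 to compound 4 (0.02 log units; within the scatter), so three quite different groups at this spot on the ring read alike. The 3,5-dimethoxyphenyl amide still stands apart, with an 11-fold higher number from compound 2 to compound 4 (1.03 log units; beyond the scatter) for the exchange of the whole aryl group. Nothing measured here explains this flat reading or that gap.

Still open, on these data alone, is whether an amine, a carboxylic acid or a longer chain at this position would leave the number unmoved. A single methoxy group might also show how much of the 3,5-dimethoxyphenyl result it can carry alone.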